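A Carbamoyl Group on a Core That Spares Cells

The source may report more compounds than this note shows. Statements on the series, on what has been measured and on what is new or still open speak of the compounds shown alone.

The shared core is that of compound 1 `Nc1ncnc2c1ccn2COCCO`. In an ADME assay on BSC-1 cells (Cercopithecidae) for cytotoxicity (a higher number here means a weaker inhibitor, a lower number a stronger inhibitor), compound 1 gives > 100000 nM, a limit of the assay rather than a number. Compound 2 `N#Cc1cn(COCCO)c2ncnc(N)c12` gives in this assay > 320000 nM, again a limit. Compound 3 `N#Cc1cnc2n(COCCO)cnc(N)c1-2` gives in this assay > 100000 nM, also a limit. With both ends at limits, the step from compound 1 to compound 2 a step that the two limits leave unreadable from compound 1 to compound 2 cannot be sized; all three values rest at the limit of > 100000 nM in this assay, at which 2 of the 3 values shown sit, or (the limit of > 320000 nM in this assay, at which 1 of the 3 values shown sits).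

Compound 4 `NC(=O)c1cn(COCCO)c2ncnc(N)c12` differs from compound 1 by carbamoyl in place of hydrogen on an aromatic carbon. Within the data shown here, the one measured step that resembles this change, cyano in place of hydrogen on the same aromatic carbon, left no readable size, so nothing here points to a move in either direction in this assay. Compound 4 is therefore expected to sit at a limit as well, with an estimated 300000 nM and a range from 100000 nM to 1000000 nM. The expected step from compound 1 to compound 4 is a step that the limit leaves unreadable from compound 1 to compound 4, nothing beyond the scatter.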

Compound 4, half-maximal inhibitory concentration: > 100000 nM
Compound 4: a limit, no number (the forecaster's own chance of this, stated with the estimate: 90%); the middle value does not contradict the limit.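

Compound 4 gives > 100000 nM in this assay, a limit and not a number, and the steps to it from compound 1 and from compound 2 cannot be read. From the compounds shown here alone, whether carbamoyl or cyano in place of hydrogen on that aromatic carbon changes the cytotoxicity read-out at all stays open.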